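A few compounds are considered here, and "the series" means these few. Any claim that something is new, unique, unknown or untested is made for them only; others in the source may bear on it.

Compound 1 `O=C1CC(c2ccc(F)cc2)CN1c1cnn2c1CN(C(=O)Nc1cc(F)c(F)c(F)c1)C(C1CC1)C2` carries a 4-fluorophenyl group on a saturated ring carbon of its five-membered lactam ring. In a toxicity assay on HepG2 2.2.15 cells (Homo sapiens) for cytotoxicity, read by CellTiter-Glo (on this read-out higher numbers stand for lower toxicity in this test and lower numbers for higher toxicity in this test), compound 1 gives 32100 nM, the highest of the two numbers recorded here. Compound 2 `O=C1OC(c2ccc(F)cc2)CN1c1cnn2c1CN(C(=O)Nc1cc(F)c(F)c(F)c1)C(C1CC1)C2`, which bears a cyclic carbamate in place of that lactam, gives in this assay 3560 nM, a lower number that lies beyond the scatter. Compound 3 `O=C(Nc1cc(F)c(F)c(F)c1)N1CCCn2ncc(N3CC(c4ccccc4)CC3=O)c2C1` has only a limit of the assay in this assay, namely > 2000 nM; the limit of > 2000 nM in this assay, at which 1 of the 3 values shown sits, applies to it and gives no number. Compound 4 `O=C1CC(c2nccs2)CN1c1cnn2c1CN(C(=O)Nc1cc(F)c(F)c(F)c1)C(C1CC1)C2` differs from compound 1 by one change: 1,3-thiazol-2-yl in place of 4-fluorophenyl on a saturated ring carbon. Among the compounds with values here, no measured pair in this set shows the effect of such a change, so the expectation rests on compound 1 alone. The step of a 1.1-fold lower number from compound 1 to compound 4 (0.03 log units; within the scatter) is expected to be small and not to exceed the scatter in either direction. Compound 4 is therefore estimated to give 30000 nM in this assay, with a range from 10000 nM to 90000 nM.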

Compound 4, half-maximal cytotoxic concentration: 115000 nM
Beside the measured number, compound 4's estimate is 3.8-fold (0.58 log units) below it, outside the stated range (above it).
By their numbers in this assay, from the lowest: compound 2; then compound 1; then compound 4.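

The replacement of 4-fluorophenyl by 1,3-thiazol-2-yl on a saturated ring carbon of the lactam gives a 3.6-fold higher number from compound 1 to compound 4 (0.55 log units; beyond the scatter) in this assay, a move towards lower toxicity in this test. Within the data shown here, no earlier pair varied the group at this position, and compound 4 now shows that the read-out responds to the group held there, with the five-membered aromatic ring with 2 hetero atoms on the less toxic side of the 4-fluorophenyl group. Nothing measured here accounts for this step.

A single pair cannot tell whether the sulfur, the ring nitrogen or the smaller ring carries the step, and a pyridin-2-yl or thiophen-2-yl group on the same carbon would help to separate these. From the compounds shown here alone, whether the same change would hold on the cyclic carbamate of compound 2 also remains open.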